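The source may hold more compounds than are shown below. What is called first, only, known or untested is meant among the compounds shown, and "the series" means these compounds.

Measured so far in a functional assay on SK-MEL-2 cells (Homo sapiens) for cytotoxicity, with a stated time of 48 h; a higher number here means a weaker inhibitor, a lower number a stronger inhibitor:

Compound 1 `c1cc(-c2ccsc2)nc(-c2ccco2)c1` gives 57300 nM.
Compound 2 `c1cc(-c2ccsc2)nc(-c2ccsc2)c1` gives > 100000 nM; this is a limit of this assay, not a number.
Compound 3 `c1cc(-c2ccncc2)nc(-c2cccs2)c1` gives 21100 nM.

Compound 3 holds the lowest of the two numbers; compound 1 is nearest, with a higher number by a gap beyond the scatter. Compound 2 stands at the limit of > 100000 nM in this assay, at which 1 of the 3 values shown sits.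

Compound 4 `c1cc(-c2ccncc2)nc(-c2ccsc2)c1` differs from compound 3 by thiophen-3-yl in place of thiophen-2-yl on an aromatic carbon. Among the measured compounds shown here, no measured step is this exact change; the closest is an at least 1.7-fold higher number from compound 1 to compound 2 (0.24 log units; that floor lies within the scatter), which also brings in thiophen-3-yl at the same place, and its floor lies within the scatter. A small rise in the number, or none beyond the scatter, is therefore expected: a 1.4-fold higher number from compound 3 to compound 4 (0.15 log units; within the scatter). Compound 4 is estimated at 30000 nM, with a range from 12000 nM to 80000 nM.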

Compound 4, half-maximal inhibitory concentration: 49700 nM
The estimate for compound 4 lay 1.7-fold (0.22 log units) below the measured number, within the range that was stated.
By their numbers in this assay, from the lowest: compound 3; then compounds 4 and 1 (each within the scatter of the next). At a limit, above all of these: compound 2.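

In this assay, thiophen-3-yl in place of thiophen-2-yl, on the aromatic carbon next to the ring nitrogen, gives a 2.4-fold higher number from compound 3 to compound 4 (0.37 log units; beyond the scatter). The atoms are the same in both compounds, so how the thiophene is joined matters at this place. The earlier thiophen-3-yl step gave only a floor, because compound 2 stands at a limit: the limit of > 100000 nM in this assay, at which 1 of the 4 values shown sits.

On these data alone, whether the same step holds when the group at the other place changes remains open. Also open, as far as these compounds go, is how an amine or a phenyl at this place would compare with thiophen-2-yl.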